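Replacing the Amide Substituent of Compound 2

The source may report more compounds than this note shows. Statements on the series, on what has been measured and on what is new or still open speak of the compounds shown alone.

Of the compounds shown here, three have been measured in a functional assay on MT2 cells (Homo sapiens) for antiproliferative activity, read by MTT assay, with a stated time of 72 h; a lower number here means a stronger inhibitor of growth, a higher number a weaker inhibitor of growth. Compound 1 `O=C(COc1c(-c2ccccc2)oc2ccccc2c1=O)Nc1ccc2ccccc2c1` gives > 10000 nM, which is a limit of the assay and not a number. Compound 2 `O=C(COc1ccc2c(=O)c(-c3ccccc3)coc2c1)Nc1ccc2ccccc2c1` gives 7680 nM, the higher of the two actual numbers. Compound 3 `COc1ccc(NC(=O)COc2ccc3oc(-c4ccccc4)cc(=O)c3c2)cc1` gives 3010 nM, and this lies under the number of compound 2 by a gap beyond the scatter.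

Compound 4 `COc1ccc(NC(=O)COc2ccc3c(=O)c(-c4ccccc4)coc3c2)cc1` keeps the core of compound 2 and carries 4-methoxyphenyl in place of naphthalen-2-yl on an amide-type nitrogen. Within the data shown here, no measured pair isolates this change. Compound 3 also carries 4-methoxyphenyl on an amide-type nitrogen and gives 3010 nM, but its core differs from that of compound 2, so it offers only weak support for a gain. In this assay, a small fall in the number is therefore expected, one that may not clear the scatter. The expected change is a 1.5-fold lower number from compound 2 to compound 4 (0.19 log units; within the scatter). For compound 4, the estimated value is 5000 nM, with an expected range of 2000 nM to 10000 nM.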

Compound 4, concentration for 50% growth inhibition: 4550 nM
The estimate for compound 4 lay 1.1-fold (0.04 log units) above the measured number; the measured number falls inside the stated range.
By their numbers in this assay, from the lowest: compounds 3, 4 and 2 (each within the scatter of the next, the first and the last beyond it). At a limit, above all of these: compound 1.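

In this assay, among these compounds, the exchange of naphthalen-2-yl for 4-methoxyphenyl on the amide-type nitrogen gives a 1.7-fold lower number from compound 2 to compound 4 (0.23 log units; within the scatter), and this is the first measured pair in which this position alone differs. On the core of compound 2, then, going from two aromatic rings to one that carries a methoxy group leaves the number within the usual scatter, so this single change shows no clear gain or loss in growth inhibition. Nothing measured here offers an explanation for this result.

The compounds shown leave open whether a plain phenyl, a 4-chlorophenyl or a cyclohexyl on this nitrogen would move the number beyond the scatter. They also leave open whether the same exchange would give a similar step on the core of compound 3.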